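Notes on compound 4: chloro in place of methoxycarbonyl

This account rests on a few compounds, and the source may have more. Where it says the series, first, only, none or still open, it means among the compounds named here.

Of the compounds shown here, three of the shared core have been measured in a functional assay on Raji cells (Homo sapiens) for cytotoxicity, read by CCK-8 assay, with a stated time of 24 h; on this read-out lower numbers stand for stronger inhibition and higher numbers for weaker inhibition. Compound 1 `C=CC(=O)N1C(=O)CC(c2ccc(C)cc2)Sc2ccccc21` gives 75500 nM. Compound 2 `C=CC(=O)N1C(=O)CC(c2ccc(C(=O)OC)cc2)Sc2ccccc21` gives 89600 nM, and compound 3 `C=CC(=O)N1C(=O)CC(C)Sc2ccccc21` gives 837000 nM. Compound 2 stands second highest of the three numbers: its nearest neighbour is compound 1, which differs a 1.2-fold higher number from compound 1 to compound 2 (0.07 log units; within the scatter), while compound 3 lies far from it, with a 4-methylphenyl replaced by methyl on a saturated ring carbon giving an 11-fold higher number from compound 1 to compound 3 (1.04 log units; beyond the scatter).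

Compound 4 `C=CC(=O)N1C(=O)CC(c2ccc(Cl)cc2)Sc2ccccc21` is the next compound of the series, not yet measured. It differs from compound 2 by chloro in place of methoxycarbonyl on an aromatic carbon. For the measured compounds named here, the step that bears on this change is the one from compound 1 to compound 2, where exchanging methyl for methoxycarbonyl on the same aromatic carbon gave a 1.2-fold higher number from compound 1 to compound 2 (0.07 log units; within the scatter), that is, no step beyond the scatter. The large step from compound 1 to compound 3 concerns loss of the whole 4-methylphenyl, not a change of the group on it, and so does not speak to this step. The expectation for compound 4 is therefore a step of a 1.1-fold lower number from compound 2 to compound 4 (0.05 log units; within the scatter) in this assay, which is within the scatter. Compound 4 is estimated at 80000 nM in this assay, with a range of 35000 nM to 180000 nM.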

Compound 4, half-maximal inhibitory concentration: 18400 nM
For compound 4 the middle estimate is 4.3-fold (0.64 log units) above the measured one; the measured number lies below the stated range.
By their numbers in this assay, from the lowest: compound 4; then compounds 1 and 2 (each within the scatter of the next); then compound 3.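

In this assay the aromatic carbon para to a large group proves sensitive to its substituent, which the exchange of methyl for methoxycarbonyl, with a 1.2-fold higher number from compound 1 to compound 2 (0.07 log units; within the scatter), did not reveal. Chloro separates from both earlier groups, with a 4.9-fold lower number from compound 2 to compound 4 (0.69 log units; beyond the scatter) for its exchange with methoxycarbonyl and a 4.1-fold lower number from compound 1 to compound 4 (0.61 log units; beyond the scatter) for its exchange with methyl, so among these three groups the difference belongs to chloro alone, while methyl and methoxycarbonyl remain within the scatter of each other. On the saturated ring carbon, 4-chlorophenyl in place of methyl gives a 45-fold lower number from compound 3 to compound 4 (1.66 log units; beyond the scatter), a large step of the same class as the one for methyl in place of 4-methylphenyl, an 11-fold higher number from compound 1 to compound 3 (1.04 log units; beyond the scatter), so the aryl group matters at that carbon whichever of these two substituents it carries.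

Going by these compounds, whether the change is particular to chloro stays open, since fluoro, bromo, an amine or a carboxylic acid on the same aromatic carbon would be needed to show how far the trend extends. Nothing available bears on the reason chloro stands apart from methyl and methoxycarbonyl in this series.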